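This account rests on a few compounds, and the source may have more. Where it says the series, first, only, none or still open, it means among the compounds named here.

Of the compounds shown here, three have been measured in a functional assay on HL-60 cells (Homo sapiens) for antiproliferative activity, read by MTT assay, with a stated time of 72 h; a lower number here means a stronger inhibitor of growth, a higher number a weaker inhibitor of growth: compound 1 `CCN(CC)C(=O)N1CCN(/[N+]([O-])=N/Oc2cc(O/N=[N+](\[O-])N(C)C)c([N+](=O)[O-])cc2[N+](=O)[O-])CC1` gives 4900 nM; compound 2 `CCOC(=O)N1CCN(/[N+]([O-])=N/Oc2cc(O/N=[N+](\[O-])N(CC)CC)c([N+](=O)[O-])cc2[N+](=O)[O-])CC1` gives 5000 nM; compound 3 `CCOC(=O)N1CCN(/[N+]([O-])=N/Oc2cc(O/N=[N+](\[O-])N3CCN(C(=O)N(CC)CC)CC3)c([N+](=O)[O-])cc2[N+](=O)[O-])CC1` gives 3000 nM.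

Compound 3 has the lowest of the three numbers, but its distance to compound 1 and to compound 2 is within the scatter of this assay, so the three cannot be told apart on these values. Within the data shown here, the one step measured between compounds differing in a single place, a 1.6-fold lower number from compound 1 to compound 3 (0.21 log units; within the scatter), was also within the scatter.

Compound 4 `CCN(CC)C(=O)N1CCN(/[N+]([O-])=N/Oc2cc(O/N=[N+](\[O-])N(CC)CC)c([N+](=O)[O-])cc2[N+](=O)[O-])CC1` is the next compound. It differs from compound 3 in one place: diethylamino in place of 4-(ethoxycarbonyl)piperazin-1-yl on a double-bonded nitrogen. This is close to the reverse of the step already seen, where a dialkylamino group was swapped for the same piperazinyl group on the same double-bonded nitrogen without a change beyond the scatter. Compound 4 also shares its diethylamino end with compound 2, and compound 2 and compound 1 sit at almost the same number. Taken together, no step beyond the scatter is expected in this assay.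

The estimate for compound 4 is therefore 4500 nM, with a range from 2000 nM to 10000 nM, corresponding to an expected step of a 1.5-fold higher number from compound 3 to compound 4 (0.18 log units; within the scatter).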

Compound 4, concentration for total growth inhibition: > 10000 nM
Compound 4: no number, only a limit; the forecaster's own chance of this, stated with the estimate: 5%; at least 2.2-fold (0.34 log units) between middle value and limit.
By their numbers in this assay, from the lowest: compounds 3, 1 and 2 (each within the scatter of the next). At a limit, above all of these: compound 4.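

In this assay compound 4 gives > 10000 nM, which is a limit of the assay and not a number. On a double-bonded nitrogen whose other neighbours are a double-bonded nitrogen and an oxygen, diethylamino in place of 4-(ethoxycarbonyl)piperazin-1-yl gives an at least 3.3-fold higher number from compound 3 to compound 4 (0.52 log units; beyond the scatter), so this position can respond to a change of group beyond the scatter, which the earlier step, a 1.6-fold lower number from compound 1 to compound 3 (0.21 log units; within the scatter), did not show. The other two new steps are less telling: diethylamino in place of ethoxy on a carbonyl carbon gives an at least 2.0-fold higher number from compound 2 to compound 4 (0.30 log units; that floor lies within the scatter), and diethylamino in place of dimethylamino on the double-bonded nitrogen gives an at least 2.0-fold higher number from compound 1 to compound 4 (0.30 log units; that floor lies within the scatter), so neither can yet be told from scatter.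

On these data alone, how far the true value of compound 4 lies past its limit stays unknown, and with it the full size of all three steps: the limit of > 10000 nM in this assay, at which 1 of the 4 values shown sits. It also remains open whether a piperidine ring, a morpholine ring or a longer chain such as dipropylamino on the same nitrogen would give a number close to that of compound 3 or one at the limit.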